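The source may hold more compounds than are shown below. What is called first, only, known or untested is meant among the compounds shown, and "the series" means these compounds.

Working notes on the series. The shared core of compound 1 `O=C1c2cc(COc3ccccc3)nn2CCN1c1ccccn1` carries pyridin-2-yl on the ring amide nitrogen; in a functional assay on HEK293 cells for positive allosteric modulation of metabotropic glutamate receptor 5 (Homo sapiens), read by calcium flux (a higher number here means a larger maximal response, a lower number a smaller maximal response), compound 1 gives 69%. Compound 2 `O=C1c2cc(COc3ccccc3)nn2CCN1c1cccnc1` carries pyridin-3-yl there and in this assay compound 2 gives 64%; the step of a number 5 percentage points lower from compound 1 to compound 2 (within the scatter) is within the scatter. Compound 3 `Cc1ccc(N2CCn3nc(COc4ccccc4)cc3C2=O)nc1` carries 5-methylpyridin-2-yl and in this assay compound 3 gives 76%, the largest of the three maximal responses: against compound 1 the step of a number 7 percentage points higher from compound 1 to compound 3 (within the scatter) is within the scatter, against compound 2 the step of a number 12 percentage points higher from compound 2 to compound 3 (beyond the scatter) is beyond it. Compound 4 `COc1ccc(N2CCn3nc(COc4ccccc4)cc3C2=O)nc1` differs from compound 3 by methoxy in place of methyl on an aromatic carbon. Among the compounds with values here, no measured step exchanges methyl for methoxy; the only change at this aromatic carbon is the step of a number 7 percentage points higher from compound 1 to compound 3 (within the scatter), which stayed within the scatter, and no step in this assay has exceeded the scatter by much. For compound 4 the expectation in this assay is therefore a step of a number 2 percentage points lower from compound 3 to compound 4 (within the scatter), not beyond the scatter in either direction. Compound 4 is estimated at 74%, within 60% to 88%.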

Compound 4, largest response reached (Emax), in percent of the reference or control that the assay uses: 74%
Compound 4: the middle estimate sits on the measured number at the digits printed, within the range that was stated.
By their numbers in this assay, from the lowest: compounds 2, 1, 4 and 3 (each within the scatter of the next, the first and the last beyond it).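

In this assay this aromatic carbon, two atoms from the ring nitrogen, accepts methoxy as well as methyl: the exchange, which adds an oxygen and a hydrogen-bond acceptor, gives a number 2 percentage points lower from compound 3 to compound 4 (within the scatter) and leaves the two groups indistinguishable, while methoxy in place of hydrogen gives a number 5 percentage points higher from compound 1 to compound 4 (within the scatter) as well. Against the pyridin-3-yl compound, the step of a number 10 percentage points higher from compound 2 to compound 4 (within the scatter) stays inside the scatter, whereas a number 12 percentage points higher from compound 2 to compound 3 (beyond the scatter) lay beyond it, so the separation seen with methyl is not carried over to methoxy. Nothing available bears on the reason for these maximal responses.

From the compounds shown here alone, whether an amine, a carboxylic acid or a longer chain such as butoxy on this carbon would keep the maximal response remains open. So does whether methoxy would behave alike on the pyridin-3-yl group.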